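Methyl in Place of Hydrogen on the Pendant Phenyl

A few compounds are considered here, and "the series" means these few. Any claim that something is new, unique, unknown or untested is made for them only; others in the source may bear on it.

In a functional assay on A549 cells (Homo sapiens) for antiproliferative activity, read by MTT assay, with a stated time of 72 h (on this read-out lower numbers stand for stronger inhibition and higher numbers for weaker inhibition), three compounds have been measured so far:

compound 1 `COc1cc(-n2cnc3ccc(-c4cccc(F)c4)cc32)cc(OC)c1OC`: 5270 nM
compound 2 `COc1cc(-n2cnc3ccc(-c4ccc(Cl)cc4)cc32)cc(OC)c1OC`: > 10000 nM, a limit of this assay rather than a number
compound 3 `COc1cc(-n2cnc3ccc(-c4ccccc4)cc32)cc(OC)c1OC`: 3060 nM

Compound 3 gives the lowest of the two numbers shown, but the step of a 1.7-fold lower number from compound 1 to compound 3 (0.24 log units; within the scatter) lies within the scatter, so no order can be read from it. The value of compound 2 is a limit of this assay (the limit of > 10000 nM in this assay, at which 1 of the 3 values shown sits), and against that limit the step of an at least 3.2-fold lower number from compound 2 to compound 3 (0.51 log units; beyond the scatter) is at least modest.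

Compound 4 `COc1cc(-n2cnc3ccc(-c4cccc(C)c4)cc32)cc(OC)c1OC` differs from compound 3 in one place: methyl in place of hydrogen on an aromatic carbon. The two measured steps that bear on this change both remove a small substituent from the same ring: a 1.7-fold lower number from compound 1 to compound 3 (0.24 log units; within the scatter) stays within the scatter, while an at least 3.2-fold lower number from compound 2 to compound 3 (0.51 log units; beyond the scatter) is beyond it. Adding a methyl runs in the opposite direction, and these two steps give no sign that a small group on this ring lowers the number. Compound 4 is therefore expected to give about 4500 nM, between 2000 nM and 10000 nM. The step this estimate implies, a 1.5-fold higher number from compound 3 to compound 4 (0.17 log units; within the scatter), is expected to stay within the scatter, perhaps leaning toward a higher number.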

Compound 4, half-maximal inhibitory concentration: 3820 nM
Compound 4: middle estimate off by 1.2-fold (0.07 log units), on the high side, and the stated range covers the measured number.
By their numbers in this assay, from the lowest: compounds 3, 4 and 1 (each within the scatter of the next). At a limit, above all of these: compound 2.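

In this assay, methyl at this place on the pendant ring, meta to a large group, cannot be told apart from hydrogen, a 1.2-fold higher number from compound 3 to compound 4 (0.10 log units; within the scatter), or from fluoro, a 1.4-fold lower number from compound 1 to compound 4 (0.14 log units; within the scatter), so all three small substituents shown here now sit within the scatter of one another, and the pendant ring carries a methyl without any clear shift in the number. The earlier gap against the 4-chlorophenyl compound also reappears with 3-methylphenyl in its place, an at least 2.6-fold lower number from compound 2 to compound 4 (0.41 log units; beyond the scatter), so that gap is not confined to the unsubstituted phenyl of compound 3, though this step changes both the group and its place on the ring. The value of compound 2 is a limit and not a number, so the true size of this step remains unknown: the limit of > 10000 nM in this assay, at which 1 of the 4 values shown sits.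

The compounds shown leave open whether the gap to compound 2 follows the chloro group itself or the place it occupies on the ring. They also leave open how an amine, a carboxylic acid or a longer chain would read at the position that carries the methyl in compound 4.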